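This account rests on a few compounds, and the source may have more. Where it says the series, first, only, none or still open, it means among the compounds named here.

In a physicochemical assay for acid dissociation, compound 2 `Cc1cc(C)cc(Cc2ccc3c(NCCCNCc4ccco4)ccnc3c2)c1` gives 9.47. Compound 1 `COc1ccc(F)cc1CNCCCNc1ccnc2cc(Cc3cc(C)cc(C)c3)ccc12` gives 9.47 in this assay, and compound 3 `COc1cccc(Oc2ccc3c(NCCCNCc4cccc(OC)c4O)ccnc3c2)c1` gives 9.28; all three numbers sit within the scatter of one another. Among the compounds with values here, the one step measured between compounds that differ in a single place, no change at the digits printed from compound 1 to compound 2 (within the scatter), put furan-2-yl in place of 5-fluoro-2-methoxyphenyl on a saturated chain carbon bound to an amine nitrogen. Compound 4 `c1ccc(Cc2ccc3c(NCCCNCc4ccco4)ccnc3c2)cc1` differs from compound 2 by phenyl in place of 3,5-dimethylphenyl on a saturated chain carbon bound to an aromatic carbon. Within the data shown here, that change sits at a different place, so no measured step covers it directly, and nothing among the three measured numbers points to a shift. For compound 4 the expected step is a number 0.02 log units lower from compound 2 to compound 4 (within the scatter), none beyond the scatter. Compound 4 is estimated at 9.45, with a range from 9.15 to 9.75.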

Compound 4, acid dissociation constant: 9.47
The estimate for compound 4 lay 0.02 log units below the measured number, within the range that was stated.
By their numbers in this assay, from the lowest: compounds 3, 1, 2 and 4 (each within the scatter of the next).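

Putting phenyl in place of 3,5-dimethylphenyl on a saturated chain carbon bound to an aromatic carbon gives, in this assay, no change at the digits printed from compound 2 to compound 4 (within the scatter). Within the data shown here, this is the first measured step at this place; the earlier step changed a different place, on a carbon bound to an amine nitrogen. No measurement at hand offers an explanation for this result.

Both groups here are carbon-only aromatic rings, so the compounds shown leave open what an amine or a carboxylic acid at this place would do to the number.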